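A few compounds are considered here, and "the series" means these few. Any claim that something is new, unique, unknown or untested is made for them only; others in the source may bear on it.

Compound 1 `CS(=O)(=O)c1ccc(Cc2n[nH]c(=S)n2/N=C/c2cccnc2)cc1` gives 16.9% in a functional assay on HeLa cells (Homo sapiens) for cytotoxicity, read by MTT assay, with a stated time of 48 h, tested at 12.5 uM (on this read-out lower numbers stand for a weaker effect and higher numbers for a stronger effect at the one concentration tested), the lowest of the three measured values. Compound 2 `CS(=O)(=O)c1ccc(Cc2n[nH]c(=S)n2/N=C/c2ccc(Cl)cc2)cc1` gives 44.7% in this assay, and compound 3 `CS(=O)(=O)c1ccc(Cc2n[nH]c(=S)n2/N=C/c2c(F)cccc2Cl)cc1` gives 49.8%. The step to compound 4 `CS(=O)(=O)c1ccc(Cc2n[nH]c(=S)n2/N=C/c2ccccc2F)cc1` is 2-fluorophenyl in place of pyridin-3-yl on a carbon with a double bond to nitrogen. For the measured compounds named here, two measured steps bear on it: a number 27.8 percentage points higher from compound 1 to compound 2 (beyond the scatter) and a number 32.9 percentage points higher from compound 1 to compound 3 (beyond the scatter), each replacing the same pyridin-3-yl with a phenyl carrying one or two halogens. The step of a number 5.1 percentage points higher from compound 2 to compound 3 (within the scatter) shows that these two phenyl variants do not differ beyond the scatter. Compound 4 carries a third halogenated phenyl of this kind, so a rise of similar size is expected, a number 27.1 percentage points higher from compound 1 to compound 4 (beyond the scatter). Compound 4 is therefore estimated at 44%, within a range from 28% to 60%.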

Compound 4, a percentage reported as activity, at one concentration (the size of the read-out at that concentration, not a potency): 16.5%
For compound 4 the middle estimate is 27.5 percentage points above the measured one; the measured number lies below the stated range.
By their numbers in this assay, from the lowest: compounds 4 and 1 (each within the scatter of the next); then compounds 2 and 3 (each within the scatter of the next).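

In this assay, a halogen on the phenyl at this carbon is not enough to raise the number: 2-fluorophenyl in place of pyridin-3-yl gives a number 0.4 percentage points lower from compound 1 to compound 4 (within the scatter). Hydrogen in place of chloro gives a number 33.3 percentage points lower from compound 3 to compound 4 (beyond the scatter), and 2-fluorophenyl in place of 4-chlorophenyl gives a number 28.2 percentage points lower from compound 2 to compound 4 (beyond the scatter), so among these four compounds the higher numbers occur only with a chloro present. Nothing measured here explains this difference. On these data alone, what an unsubstituted phenyl, a bromo-substituted phenyl or a methoxy-substituted phenyl would give at this carbon remains open.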